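Swapping an Isopropyl for Iodine on the Sulfonate Ester

This account rests on a few compounds, and the source may have more. Where it says the series, first, only, none or still open, it means among the compounds named here.

Measured compounds:
Compound 1, `CC(C)(C)C(=O)Nc1ccc(S(=O)(=O)Oc2ccccc2I)cc1`: 8300 nM
Compound 2, `CC(C)c1ccccc1OS(=O)(=O)c1ccc(NC(=O)CCCl)cc1`: 14000 nM

Compound 1, `CC(C)(C)C(=O)Nc1ccc(S(=O)(=O)Oc2ccccc2I)cc1`, and compound 2, `CC(C)c1ccccc1OS(=O)(=O)c1ccc(NC(=O)CCCl)cc1`, share a core of a para-acylaminobenzenesulfonate ester of a phenol. In a functional assay on M21 cells (Homo sapiens) for antiproliferative activity, read by sulforhodamine B assay, with a stated time of 48 h (a higher number here means a weaker inhibitor, a lower number a stronger inhibitor), compound 1 gives 8300 nM. In this assay compound 2 gives 14000 nM. These two numbers lie within the usual scatter of one another, so neither compound can be called the stronger or the weaker of the pair; both are weak inhibitors of cell growth.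

Compound 3, `O=C(CCCl)Nc1ccc(S(=O)(=O)Oc2ccccc2I)cc1`, keeps the chloropropanamide of compound 2 and changes the phenol side: iodo in place of isopropyl on an aromatic carbon. Within the data shown here, no directly comparable pair of measured compounds shows what this exchange does on its own. Since compound 1 carries this same iodo group and compound 2 this same isopropyl group, with both at similar weak values, the step from compound 2 to compound 3 in this assay is expected to stay within the scatter, in either direction.

Compound 3 is therefore estimated at 10000 nM in this assay, with a plausible range from 4000 nM to 25000 nM, a change of a 1.4-fold lower number from compound 2 to compound 3 (0.15 log units; within the scatter) that is not expected to exceed the scatter.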

Compound 3, half-maximal inhibitory concentration: 12000 nM
For compound 3 the middle estimate is 1.2-fold (0.08 log units) below the measured one; low and high end bracket the measured number.
By their numbers in this assay, from the lowest: compounds 1, 3 and 2 (each within the scatter of the next).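

In this assay, the exchange of isopropyl for iodo on an aromatic carbon, ortho to a large group, can now be read on its own, with the chloropropanamide held fixed: it gives a 1.2-fold lower number from compound 2 to compound 3 (0.07 log units; within the scatter) and so does not separate the two groups at this position. With the iodo group held fixed, the acyl end can be read as well: 2-chloroethyl in place of tert-butyl on a carbonyl carbon gives a 1.4-fold higher number from compound 1 to compound 3 (0.16 log units; within the scatter) and so does not separate those two groups either. No measurement beyond these cell-growth numbers is available to explain either result.

Both steps therefore describe a small set of exchanges among compounds that all remain weak inhibitors of cell growth, and they cannot be extended to other groups. Still open, on these data alone, is whether a plain hydrogen, an amine or a carboxylic acid on that aromatic carbon, or a longer chain on the carbonyl carbon, would move the number beyond the usual scatter.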